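The source may report more compounds than this note shows. Statements on the series, on what has been measured and on what is new or still open speak of the compounds shown alone.

Measured compounds:
- Compound 1 `CC(C)Oc1ccc(-c2cc(C(=O)O)nn2-c2ccccc2)cc1`: in an assay for displacement of a labelled ligand from E3 ubiquitin-protein ligase Mdm2 (Homo sapiens), read by fluorescence polarization, with a stated time of 30 min (on this read-out higher numbers stand for weaker inhibition and lower numbers for stronger inhibition), compound 1 gives 2290 nM
- Compound 2 `CCOc1ccc(-c2cc(C(=O)O)nn2-c2ccc(Oc3ccccc3)cc2)cc1`: in this assay compound 2 gives 1030 nM

Compound 2 has the lower of the two numbers, which on this read-out means the stronger binding; compound 1 sits above it by a gap that is beyond the usual scatter. Going by the values given here, the two compounds differ from each other in two places at once, so no single step connects them and only their two values can be compared.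

Compound 3 `CC(C)Oc1ccc(-c2cc(C(=O)O)nn2-c2ccc(Oc3ccccc3)cc2)cc1` is built from compound 2 by one small change: methyl in place of hydrogen on a saturated chain carbon bound to an oxygen on an aromatic ring and a saturated chain carbon. Nothing measured here isolates the effect of that change. A single added carbon at such a place is expected to move the number little, and the step of a 1.1-fold lower number from compound 2 to compound 3 (0.06 log units; within the scatter) is estimated to stay within the scatter, in no clear direction. Compound 3 is therefore expected to give about 900 nM, with a likely range from 400 nM to 2500 nM.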

Compound 3, inhibition constant: 712 nM
The estimate for compound 3 lay 1.3-fold (0.10 log units) above the measured number, within the range that was stated.
By their numbers in this assay, from the lowest: compounds 3 and 2 (each within the scatter of the next); then compound 1.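

In this assay, the move from ethoxy to isopropoxy gives a 1.4-fold lower number from compound 2 to compound 3 (0.16 log units; within the scatter), so this saturated chain carbon bound to an oxygen on an aromatic ring accepts an added methyl with no clear shift in the number. Compound 3 also links the other two compounds through a change in one place, which shows what the two-place comparison could not: phenoxy in place of hydrogen on an aromatic carbon gives a 3.2-fold lower number from compound 1 to compound 3 (0.51 log units; beyond the scatter), a modest step but one beyond the scatter. No further measurement here bears on why either step has its size.

As far as these compounds go, whether a longer chain such as butoxy would read the same as isopropoxy remains open. So does what a smaller group such as methoxy or chlorine would do in place of phenoxy.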